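Trading cyclopropyl for 4-ethylphenyl on the amine nitrogen

The source may hold more compounds than are shown below. What is called first, only, known or untested is meant among the compounds shown, and "the series" means these compounds.

Compound 1 `Cc1ccc(NC2=CC(=O)c3nc4n(c3C2=O)[C@H]2OC[C@@H](O)[C@H]2OC4)cc1C` gives 2080 nM in this assay.
Compound 2 `O=C1C(NC2CC2)=CC(=O)c2c1nc1n2[C@H]2OC[C@@H](O)[C@H]2OC1` is reported only as a limit, > 16000 nM.
Compound 3 `O=C1C=C(NC2CCCCC2)C(=O)c2c1nc1n2[C@H]2OC[C@@H](O)[C@H]2OC1` is reported only as a limit, > 8000 nM.

The read-out is a functional assay on MCF7 cells (Homo sapiens) for inhibition, read by sulforhodamine B assay; a lower number here means a stronger inhibitor, a higher number a weaker inhibitor. Compound 1 gives a number, 2080 nM. Compound 2 stands at the limit of > 16000 nM in this assay, at which 1 of the 3 values shown sits, a limit rather than a measured number, so nothing finer is known about it than that it is a weak inhibitor. Compound 3 stands at the limit of > 8000 nM in this assay, at which 1 of the 3 values shown sits, also a limit.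

Compound 4 `CCc1ccc(NC2=CC(=O)c3c(nc4n3[C@H]3OC[C@@H](O)[C@H]3OC4)C2=O)cc1` is built from compound 2 by 4-ethylphenyl in place of cyclopropyl on an amine nitrogen. Among the compounds with values here, one measured step bears on this change, and it runs the opposite way: an at least 3.8-fold higher number from compound 1 to compound 3 (0.58 log units; beyond the scatter), where a cyclohexyl replaced a 3,4-dimethylphenyl and the number rose. Putting a six-membered aromatic ring back onto the amine nitrogen in place of a small saturated ring is therefore expected to move the number down. Compound 4 is expected to land near compound 1, around 3000 nM, between 1000 nM and 10000 nM. That corresponds to an expected step of an at least 5.3-fold lower number from compound 2 to compound 4 (0.72 log units; beyond the scatter).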

Compound 4, half-maximal inhibitory concentration: 8990 nM
For compound 4 the middle estimate is 3.0-fold (0.48 log units) below the measured one, and the stated range covers the measured number.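

With 4-ethylphenyl on the amine nitrogen, compound 4 gives a measured number in this assay where cyclopropyl left only a limit. Within the data shown here, that number is higher than the one for compound 1 with its 3,4-dimethylphenyl group, at 2080 nM. The change reads as an at least 1.7-fold lower number from compound 2 to compound 4 (0.25 log units; that floor lies within the scatter), so on its own it does not establish a real gain. Compound 2 remains a limit, so the true size of this change stays unknown: the limit of > 16000 nM in this assay, at which 1 of the 4 values shown sits.

Among these compounds, only two substituted phenyl groups appear on this nitrogen, so it remains open whether the ring or its substituents set the number. On these data alone, how an unsubstituted phenyl, a 4-methoxyphenyl or a benzyl group would read at this amine nitrogen is also open.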